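This account rests on a few compounds, and the source may have more. Where it says the series, first, only, none or still open, it means among the compounds named here.

Compound 3 `COc1cc(N)c(Cl)cc1C(=O)N[C@H]1CCN(CCCn2cccc2)C[C@H]1OC` gives 648 nM in an assay on COS-7 cells for displacement of a labelled ligand from 5-hydroxytryptamine receptor 4 (Homo sapiens), read by scintillation counting, with a stated time of 30 min (on this read-out lower numbers stand for stronger inhibition and higher numbers for weaker inhibition), the highest of the three numbers recorded; compound 2 `COc1cc(N)c(Cl)cc1C(=O)N[C@H]1CCN(CC2CCN(C(C)=O)CC2)C[C@H]1OC` stands nearest with 592 nM, a gap within the scatter, while compound 1 `COc1cc(N)c(Cl)cc1C(=O)N[C@H]1CCN(CC2CCN(C(=O)CC(C)C)CC2)C[C@H]1OC` lies furthest at 78 nM. Compound 4 `COc1cc(N)c(Cl)cc1C(=O)N[C@H]1CCN(CC2CCN(C(=O)N(C)C)CC2)C[C@H]1OC` differs from compound 3 by 1-(dimethylcarbamoyl)piperidin-4-yl in place of 2-(1H-pyrrol-1-yl)ethyl on a saturated chain carbon bound to an amine nitrogen in a ring. Within the data shown here, two measured steps bear on this. The step of a 1.1-fold higher number from compound 2 to compound 3 (0.04 log units; within the scatter) shows that exchanging an acylated piperidinyl for the pyrrolylethyl chain changed little, so reversing it should return roughly to the level of compound 2. The step of a 7.6-fold higher number from compound 1 to compound 2 (0.88 log units; beyond the scatter) shows that a larger acyl group on that piperidine nitrogen gave a markedly lower number, and the dimethylcarbamoyl group is larger than acetyl. Compound 4 is therefore expected to show a 2.3-fold lower number from compound 3 to compound 4 (0.36 log units; beyond the scatter), with an estimated value of 280 nM (range 90 nM to 900 nM).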

Compound 4, half-maximal inhibitory concentration: 52 nM
The estimate for compound 4 lay 5.4-fold (0.73 log units) above the measured number, outside the stated range (below it).
By their numbers in this assay, from the lowest: compounds 4 and 1 (each within the scatter of the next); then compounds 2 and 3 (each within the scatter of the next).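

On a saturated chain carbon bound to an amine nitrogen in a ring, the position proved sensitive to the group it carries: the change to 1-(dimethylcarbamoyl)piperidin-4-yl gave a 12-fold lower number from compound 3 to compound 4 (1.10 log units; beyond the scatter), a separation the acetyl compound had not shown. On the carbonyl carbon, dimethylamino in place of methyl gave an 11-fold lower number from compound 2 to compound 4 (1.06 log units; beyond the scatter) and so mattered greatly, while dimethylamino in place of isobutyl gave a 1.5-fold lower number from compound 1 to compound 4 (0.18 log units; within the scatter) and left the two compounds level. No measurement shown accounts for these results. Open, on these data alone, is whether methoxy or a pyrrolidine in place of dimethylamino on the carbonyl carbon would keep the number at this level.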